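This account rests on a few compounds, and the source may have more. Where it says the series, first, only, none or still open, it means among the compounds named here.

Measured compounds:
- Compound 1 `O=C1c2ccc(OCc3cccc(-c4ccc(C(F)(F)F)cc4F)c3)cc2CN1C1CCCC1` with "not determined" (no result reported) in the only read-out available
- Compound 2 `COc1ccc(-c2cccc(COc3ccc4c(c3)CN(C3CCCC3)C4=O)c2)cc1C(=O)O` with 100% in the same read-out

Among the compounds with values here, in an ADME assay on a cell-free system (plasma, Rattus norvegicus) for metabolic stability, read by LC-MS, with a stated time of 1 h, at 37 degrees C, tested at 100 uM (on this read-out lower numbers stand for a less stable compound and higher numbers for a more stable compound), compound 2 gives 100% as the only number available, and compound 1 has no reported result. Compound 3 `O=C(O)c1cc(F)cc(-c2cccc(COc3ccc4c(c3)CN(C3CCCC3)C4=O)c2)c1` is still to be measured in this assay and departs from compound 2 at one place: 3-carboxy-5-fluorophenyl in place of 3-carboxy-4-methoxyphenyl on an aromatic carbon. Within the data shown here, no measured pair of compounds shows what such a change does here, so the expectation rests on compound 2 at 100% alone. The expected a number 4 percentage points lower from compound 2 to compound 3 (within the scatter) is small, pointing slightly downward and staying within the usual scatter. The estimated value for compound 3 is 96%, with an expected range of 84% to 104% for repeated measurements.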

Compound 3, percent of the compound remaining: 95%
Compound 3: middle estimate off by 1 percentage points, on the high side, and the stated range covers the measured number.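

In this assay, the first step measured at this place, meta to a large group, exchanges 3-carboxy-4-methoxyphenyl for 3-carboxy-5-fluorophenyl and gives a number 5 percentage points lower from compound 2 to compound 3 (within the scatter). On this read-out, the two compounds cannot be told apart, so the exchange of these two carboxy-bearing rings leaves no measurable mark. No measurement shown offers an explanation for this result.

Both numbers come from compounds carrying the carboxylic acid, so the compounds shown leave open what happens when an amine or a nitrile takes its place. From the compounds shown here alone, the methoxy group and the fluorine also differ together in this single step, and their separate contributions remain open.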